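This account rests on a few compounds, and the source may have more. Where it says the series, first, only, none or still open, it means among the compounds named here.

compound 1 `Cn1c(=O)c(S(=O)(=O)c2ccc(F)cc2F)cc2cnc(Nc3cccc4[nH]ccc34)nc21`: 1500 nM
compound 2 `Cn1c(=O)c(S(=O)(=O)c2ccc(F)cc2F)cc2cnc(Nc3ccc4sccc4c3)nc21`: 500 nM
compound 3 `Cn1c(=O)c(S(=O)(=O)c2ccc(F)cc2F)cc2cnc(Nc3ccncn3)nc21`: 30000 nM

In a functional assay on K562 cells (Homo sapiens) for inhibition, read by trypan blue exclusion, with a stated time of 72 h (on this read-out lower numbers stand for stronger inhibition and higher numbers for weaker inhibition), compound 3 gives the highest number of the three, 30000 nM, and so is the weakest inhibitor so far. The next compound to be tested, compound 4 `Cn1c(=O)c(S(=O)(=O)c2ccc(F)cc2F)cc2cnc(Nc3ccc4c(c3)CC(=O)N4)nc21`, changes only the group on the nitrogen: a group of 10 heavy atoms (8 carbon, 1 nitrogen, 1 oxygen; one five-membered non-aromatic ring with 1 hetero atom, one six-membered aromatic ring of carbon only) in place of a group of 6 heavy atoms (4 carbon, 2 nitrogen; one six-membered aromatic ring with 2 hetero atoms), on a nitrogen on an aromatic ring. Within the data shown here, two measured steps bear most directly on this. Putting pyrimidin-4-yl in place of a larger group with two rings gave large rises, a 20-fold higher number from compound 1 to compound 3 (1.30 log units; beyond the scatter) and a 60-fold higher number from compound 2 to compound 3 (1.78 log units; beyond the scatter). The two larger groups differ far less from each other, a 3.0-fold lower number from compound 1 to compound 2 (0.48 log units; beyond the scatter). Compound 4 also swaps pyrimidin-4-yl for a larger group with two rings, so a large fall in this assay is expected, roughly undoing those rises. However, neither compound 1 nor compound 2 has the carbonyl of the new group, which keeps the range wide. The expected change is a 30-fold lower number from compound 3 to compound 4 (1.48 log units; beyond the scatter). Compound 4 is estimated at 1000 nM, within an expected range of 250 nM to 5000 nM.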

Compound 4, half-maximal inhibitory concentration: 15000 nM
Beside the measured number, compound 4's estimate is 15-fold (1.18 log units) below it; the measured number lies above the stated range.
By their numbers in this assay, from the lowest: compound 2; then compound 1; then compounds 4 and 3 (each within the scatter of the next).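

Greater size alone does not bring back activity on this nitrogen: in this assay the new group with two rings leaves compound 4 no clearly apart from the single-ring pyrimidin-4-yl compound, the step being a 2.0-fold lower number from compound 3 to compound 4 (0.30 log units; within the scatter). Two-ring groups are also far from interchangeable here, as the steps show: a 30-fold higher number from compound 2 to compound 4 (1.48 log units; beyond the scatter) and a 10-fold higher number from compound 1 to compound 4 (1.00 log units; beyond the scatter). No measurement at hand explains why the group with the carbonyl and the amide hydrogen departs from the other two-ring groups.

Whether the carbonyl itself accounts for this gap stays open, since no compound shown carries the same two-ring group without it. Also open, going by these compounds, is how a plain phenyl ring, or one carrying a methoxy group or an amine, would compare on this nitrogen.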